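Bromo in place of hydrogen on an aryl pyrazoline

A few compounds are considered here, and "the series" means these few. Any claim that something is new, unique, unknown or untested is made for them only; others in the source may bear on it.

Measured compounds:
compound 1 `CNC(=O)c1cc(Oc2ccc(C3=NNC(c4ccc(C#N)cc4)C3)cc2)ccn1` — 9910 nM
compound 2 `CNC(=O)c1cc(Oc2ccc(C3=NNC(c4ccccc4)C3)cc2)ccn1` — 4520 nM

The two measured compounds share a core and differ only at one aromatic carbon. In a functional assay on PC-3 cells (Homo sapiens) for cytotoxicity, read by MTT assay, with a stated time of 72 h (a higher number here means a weaker inhibitor, a lower number a stronger inhibitor), compound 1 gives 9910 nM, and compound 2 gives 4520 nM. For the measured compounds named here, compound 2 thus stands with the lowest number of the two; its nearest neighbour is compound 1, and the single step that connects them is a 2.2-fold lower number from compound 1 to compound 2 (0.34 log units; beyond the scatter).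

Compound 3 `CNC(=O)c1cc(Oc2ccc(C3=NNC(c4ccc(Br)cc4)C3)cc2)ccn1` is not yet measured. It differs from compound 2 by bromo in place of hydrogen on an aromatic carbon, at the same aromatic carbon where compound 1 carries its cyano group. Going by the values given here, only the one step from compound 1 to compound 2 bears on this change, and it was modest, showing that removing a substituent from this carbon lowered the number. Bromo is a different group from cyano, so that step sets no firm direction here; a step no larger than the one already seen, in either direction, seems plausible in this assay.

Compound 3 is therefore expected to give about 3500 nM, within a range of 1500 nM to 9000 nM, which corresponds to an estimated step of a 1.3-fold lower number from compound 2 to compound 3 (0.11 log units; within the scatter).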

Compound 3, half-maximal inhibitory concentration: > 50000 nM
Compound 3: only a limit was reported (the forecaster's own chance of this, stated with the estimate: 5%); middle value at least 14-fold (1.15 log units) away from the limit.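

In this assay compound 3 carries only a limit, > 50000 nM, and the reading ends there: the limit of > 50000 nM in this assay, at which 1 of the 3 values shown sits.

Even so, this carbon proves far less forgiving than the earlier pair suggested: bromo in place of hydrogen, on the aromatic carbon para to a large group, gives an at least 11-fold higher number from compound 2 to compound 3 (1.04 log units; beyond the scatter), a large step beside the modest 2.2-fold lower number from compound 1 to compound 2 (0.34 log units; beyond the scatter). Bromo in place of cyano at the same carbon also gives an at least 5.0-fold higher number from compound 1 to compound 3 (0.70 log units; beyond the scatter), so among these three compounds a substituent here does not shift the number by one shared amount, and which group stands on this carbon decides the size of the step.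

The compounds shown leave open whether so steep a rise belongs to bromo alone or would also appear with a fluoro group, a chloro group or a methoxy group on this carbon. They also leave open how far the true value of compound 3 lies past its limit, so both of its steps are known only as minimum sizes.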